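The compounds below may be only part of what the source reports. "The series", "measured", "known", "first", "only" and "open" are said of these compounds alone.

Measured compounds in an assay on HEK293 cells for displacement of a labelled ligand from NPC1-like intracellular cholesterol transporter 1 (Homo sapiens); on this read-out lower numbers stand for stronger inhibition and higher numbers for weaker inhibition:
- Compound 2, `CC(C)(C)c1ccc(C(=O)N2CCC3(CC2)C(=O)N(CC(=O)NCCCCNS(C)(=O)=O)CN3c2ccccc2)cc1`, gives 4500 nM in this assay.
- Compound 3, `CC(C)(C)c1ccc(C(=O)N2CCC3(CC2)C(=O)N(CC(=O)N2CCNCC2)CN3c2ccccc2)cc1`, gives 22000 nM in this assay.
- Compound 1, `COC(=O)CCCNC(=O)CN1CN(c2ccccc2)C2(CCN(C(=O)c3ccc(C(C)(C)C)cc3)CC2)C1=O`, has "not determined" (no result reported) in this assay.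

Compound 3 therefore carries the higher of the two available numbers, meaning the weaker binding. Among the measured compounds shown here, the one measured step that is known, a 4.9-fold higher number from compound 2 to compound 3 (0.69 log units; beyond the scatter), shows that exchanging the (4-(methanesulfonamido)butyl)amino side chain of compound 2 for a piperazin-1-yl ring weakened binding by a modest but real margin.

Compound 4, `CC(C)(C)c1ccc(C(=O)N2CCC3(CC2)C(=O)N(CC(=O)NCCCNS(C)(=O)=O)CN3c2ccccc2)cc1`, is the next compound to be measured. The change from compound 3 is (3-(methanesulfonamido)propyl)amino in place of piperazin-1-yl on a carbonyl carbon. This largely undoes the earlier step: the ring leaves again and a methanesulfonamido-bearing chain returns, now as the propyl rather than the butyl homologue seen in compound 2. For the measured compounds named here, since the only relevant step runs in the reverse direction with a modest size, the expectation is that compound 4 moves back toward the value of compound 2, with some room for the shorter chain to shift the result either way.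

The expected step is a 4.4-fold lower number from compound 3 to compound 4 (0.64 log units; beyond the scatter). Compound 4 is thus estimated at 5000 nM, within a range from 2000 nM to 15000 nM.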

Compound 4, half-maximal inhibitory concentration: 10400 nM
Compound 4: the middle estimate sits 2.1-fold (0.32 log units) below what was measured, and the stated range covers the measured number.
By their numbers in this assay, from the lowest: compound 2; then compound 4; then compound 3.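

In this assay, replacing the piperazin-1-yl ring on this carbonyl carbon with an open chain ending in methanesulfonamido again gives a lower number, a 2.1-fold lower number from compound 3 to compound 4 (0.33 log units; beyond the scatter), so the earlier result with the butyl chain also holds for a propyl chain. The new compound also shows that chain length at this position can be read in the data: moving from the butyl to the propyl homologue gives a 2.3-fold higher number from compound 2 to compound 4 (0.36 log units; beyond the scatter), a modest step but beyond the usual scatter. The three measured compounds therefore run from the butyl chain, through the propyl chain, to the piperazin-1-yl ring, and nothing measured here explains this order.

As far as these compounds go, whether a pentyl chain with the same methanesulfonamido end would lower the number further remains open, as only the propyl and butyl lengths can be compared so far. Also open, from the compounds shown here alone, is how much the methanesulfonamido end itself contributes, and a chain of the same length ending in a primary amine or a carboxylic acid would be the comparison that speaks to this.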